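A few compounds are considered here, and "the series" means these few. Any claim that something is new, unique, unknown or untested is made for them only; others in the source may bear on it.

Measured compounds:
- compound 1 `CN(C(=O)C(C)(C)C)c1ccc2[nH]c(-c3n[nH]c4ccccc34)cc2n1`: 22200 nM
- compound 2 `CN(C(=O)c1ccc(Br)cc1)c1ccc2[nH]c(-c3n[nH]c4ccccc34)cc2n1`: 3460 nM

In a functional assay on SMMC-7721 cells (Homo sapiens) for antiproliferative activity, read by MTT assay, with a stated time of 72 h (on this read-out higher numbers stand for weaker inhibition and lower numbers for stronger inhibition), compound 1 gives 22200 nM, the highest of the two numbers shown. The nearest neighbour is compound 2, which in this assay gives 3460 nM; that step, a 6.4-fold lower number from compound 1 to compound 2 (0.81 log units; beyond the scatter), exchanges the tert-butyl on the carbonyl carbon for an aryl group.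

Compound 3 `CN(C(=O)c1ccc([N+](=O)[O-])cc1)c1ccc2[nH]c(-c3n[nH]c4ccccc34)cc2n1` has not yet been tested. Relative to compound 1 the change is 4-nitrophenyl in place of tert-butyl on a carbonyl carbon. Among the measured compounds shown here, the only step that bears on it is the one from compound 1 to compound 2, again an aryl group in place of tert-butyl at the same carbonyl carbon, which gave a 6.4-fold lower number from compound 1 to compound 2 (0.81 log units; beyond the scatter). On that basis a downward step of a similar size, beyond the scatter, is expected in this assay for compound 3, with the different substituent on the phenyl ring adding uncertainty. The expected step is a 5.6-fold lower number from compound 1 to compound 3 (0.74 log units; beyond the scatter). For compound 3 the estimate is 4000 nM, with a range of 1500 nM to 12000 nM.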

Compound 3, half-maximal inhibitory concentration: 18400 nM
Estimate against measurement, compound 3: 4.6-fold (0.66 log units) below; measured number outside the range, above it.
By their numbers in this assay, from the lowest: compound 2; then compounds 3 and 1 (each within the scatter of the next).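

In this assay, an aryl group in place of tert-butyl on the carbonyl carbon does not carry a fixed result: with 4-nitrophenyl the change gives a 1.2-fold lower number from compound 1 to compound 3 (0.08 log units; within the scatter). The substituent on the phenyl ring therefore counts at this position, as nitro in place of bromo on an aromatic carbon gives a 5.3-fold higher number from compound 2 to compound 3 (0.73 log units; beyond the scatter). Nothing on hand accounts for this difference between bromo and nitro.

Open, from the compounds shown here alone, is whether the lower number of compound 2 is specific to bromo or would recur with an unsubstituted phenyl, a 4-chlorophenyl or a 4-methoxyphenyl at the same carbonyl carbon. Also open, going by these compounds, is how a 4-aminophenyl or a 4-carboxyphenyl would stand.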